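Fluoro in place of methyl on an aromatic carbon

A few compounds are considered here, and "the series" means these few. Any claim that something is new, unique, unknown or untested is made for them only; others in the source may bear on it.

Measured so far:
compound 1, `CNC(=O)c1oncc1-c1ccccc1`, gives > 25000 nM in an assay on isolated protein for inhibition of Tryptophan 2,3-dioxygenase (Homo sapiens), read by fluorescence and mass spectrometry, with stated times of 5 min and 15 min; a higher number here means a weaker inhibitor, a lower number a stronger inhibitor; this is a limit of the assay, not a number, as recorded in the limit of > 25000 nM in this assay, at which 1 of the 3 values shown sits.
compound 2, `Nc1oncc1-n1cccn1`, gives 290 nM in this assay.
compound 3, `Cc1cnn(-c2cnoc2N)c1`, gives 1600 nM in this assay.

Compound 3 stands at the highest of the two numbers shown. Its nearest neighbour is compound 2, and the step of a 5.5-fold higher number from compound 2 to compound 3 (0.74 log units; beyond the scatter) separates the two; that step is methyl in place of hydrogen on an aromatic carbon, so the measured pair shows that what sits on this carbon changes the number well beyond the scatter.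

The unmeasured compound 4, `Nc1oncc1-n1cc(F)cn1`, differs from compound 3 by fluoro in place of methyl on an aromatic carbon. Going by the values given here, the one measured step that touches this carbon is a 5.5-fold higher number from compound 2 to compound 3 (0.74 log units; beyond the scatter), which went toward weaker inhibition when methyl replaced hydrogen. Fluoro is neither hydrogen nor methyl, so the new step has no exact twin among the measured ones. The expectation is a move back toward compound 2, but only part of the way: the step of a 2.3-fold lower number from compound 3 to compound 4 (0.36 log units; beyond the scatter) is the estimated change in this assay. For compound 4 the estimate is 700 nM, with a range from 250 nM to 2500 nM.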

Compound 4, half-maximal inhibitory concentration: 340 nM
Beside the measured number, compound 4's estimate is 2.1-fold (0.31 log units) above it; low and high end bracket the measured number.
By their numbers in this assay, from the lowest: compounds 2 and 4 (each within the scatter of the next); then compound 3. At a limit, above all of these: compound 1.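

Changing methyl to fluoro on this aromatic carbon gives a 4.7-fold lower number from compound 3 to compound 4 (0.67 log units; beyond the scatter) in this assay and so undoes nearly all of what the methyl group cost. Set against the compound with hydrogen at the same carbon, the fluoro compound gives a 1.2-fold higher number from compound 2 to compound 4 (0.07 log units; within the scatter) and this assay does not separate the two groups. Going by these compounds alone, the earlier pair alone could be read as saying that any group placed on this carbon gives weaker inhibition, but compound 4 goes against that reading, so the loss seen so far belongs to methyl, the one group of the three that stands apart from the others.

As far as these compounds go, with only hydrogen, methyl and fluoro to compare at this carbon, it stays open whether chloro, methoxy, a nitrile or an amine would behave like fluoro or like methyl, and how far the number would move with each. Nothing measured among these compounds explains why methyl differs from fluoro and hydrogen at this carbon.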